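Benzyl to allyl exchange: antiproliferative working notes

The source may hold more compounds than are shown below. What is called first, only, known or untested is meant among the compounds shown, and "the series" means these compounds.

Measured in a functional assay on HOS cells (Homo sapiens) for antiproliferative activity, read by sulforhodamine B assay; a lower number here means a stronger inhibitor of growth, a higher number a weaker inhibitor of growth:
compound 1, `C=CC[C@@H]1O[C@H](COCc2ccccc2)[C@@H](OCc2ccccc2)[C@H](OCc2ccccc2)[C@H]1O`: 44100 nM
compound 2, `O[C@@H]1[C@@H](OCc2ccccc2)[C@H](OCc2ccccc2)[C@@H](COCc2ccccc2)O[C@H]1Cc1ccccc1`: 29200 nM
compound 3, `O=C1[C@H](Cc2ccccc2)O[C@H](COCc2ccccc2)[C@@H](OCc2ccccc2)[C@@H]1OCc1ccccc1`: only a limit, > 50000 nM

Compound 2 and compound 1 differ in one place, (vinyl in place of phenyl on a saturated chain carbon bound to a saturated ring carbon). The step of a 1.5-fold higher number from compound 2 to compound 1 (0.18 log units; within the scatter). Compound 3 gives only a limit in this assay, > 50000 nM; this rests on (the limit of > 50000 nM in this assay, at which 1 of the 3 values shown sits). How the core of compound 3 differs from the core of compound 2 is not broken down here.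

Compound 4, `C=CC[C@@H]1O[C@H](COCc2ccccc2)[C@@H](OCc2ccccc2)[C@H](OCc2ccccc2)C1=O`, is not yet measured. From compound 3 it carries vinyl in place of phenyl on a saturated chain carbon bound to a saturated ring carbon. The place is the same in both pairs, so this is the same change as that from compound 2 to compound 1.

For compound 4 in this assay the expected step is a step that the limit leaves unreadable from compound 3 to compound 4, resting on the step of a 1.5-fold higher number from compound 2 to compound 1 (0.18 log units; within the scatter), which left the value essentially unmoved, and on compound 3 sitting at the limit > 50000 nM. Compound 4 is therefore estimated at 60000 nM, with a range from 30000 nM to 150000 nM, and a good chance that only a limit is again reported rather than a number.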

Compound 4, concentration for 50% growth inhibition: 7600 nM
Beside the measured number, compound 4's estimate is 7.9-fold (0.90 log units) above it; measured number outside the range, below it.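

In this assay the benzyl to allyl exchange gives an at least 6.5-fold lower number from compound 3 to compound 4 (0.81 log units; beyond the scatter), so on the core of compound 3 the change moves the value, and this result does not carry over from the core of compound 2, where the same exchange gives a 1.5-fold higher number from compound 2 to compound 1 (0.18 log units; within the scatter): the same change on two cores in this assay, a 1.5-fold higher number (0.18 log units; within the scatter) from compound 2 to compound 1 and an at least 6.5-fold lower number (0.81 log units; beyond the scatter) from compound 3 to compound 4, at least 9.9-fold (0.99 log units) apart, beyond the scatter of two such steps

Compound 3 stands at a limit and not a number, so the step on its core has a known lower bound but no known full size: the limit of > 50000 nM in this assay, at which 1 of the 4 values shown sits.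

The two pairs show that the result of this exchange depends on the core among these four compounds, but they do not show what in the cores sets the difference, and two pairs give no rule for any further core.

The compounds shown leave open whether the step on the core of compound 3 belongs to allyl specifically or would also appear with a plain propyl chain, a longer chain or an amine at the same place. Going by these compounds, it also remains open whether compound 4, at 7600 nM, marks a level that other groups on this core could pass, for instance a carboxylic acid on the end of the chain.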